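The source may hold more compounds than are shown below. What is called first, only, known or untested is meant among the compounds shown, and "the series" means these compounds.

The series rests on one shared core, seen in compound 1 `O=C(Nc1ccncc1)Nc1ccccc1[N+](=O)[O-]`. In a functional assay on the whole organism with Mus musculus as the target, in the maximal electroshock model, with a stated time of 30 min (a higher number here means that more compound is needed for the effect, a lower number that less compound is needed), compound 1 gives 300 mg/kg. Compound 2 `O=C(Nc1ccncc1)Nc1c(Cl)cccc1Cl` gives 100 mg/kg, and compound 3 `Cc1cccc(Cl)c1NC(=O)Nc1ccncc1` gives 30 mg/kg. Compound 2 therefore stands second highest of the three numbers: compound 1 sits at a higher number, beyond the scatter, and compound 3 at a lower one, also beyond the scatter. Within the data shown here, the only step measured between compounds that differ in one place is a 3.3-fold lower number from compound 2 to compound 3 (0.52 log units; beyond the scatter), a modest move.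

Compound 4 `O=C(Nc1ccncc1)Nc1c(Cl)cc(Cl)cc1Cl` differs from compound 2 in one place: chloro in place of hydrogen on an aromatic carbon. Among the measured compounds shown here, no measured step puts chloro in place of hydrogen anywhere; the single step that involves a chloro group is a 3.3-fold lower number from compound 2 to compound 3 (0.52 log units; beyond the scatter), and it replaces that group by methyl rather than adding a further one, so it bears on the present change only loosely. With nothing that tracks the change directly, no step beyond the scatter is expected in either direction. For compound 4 the number in this assay is expected near 100 mg/kg, within a range from 30 mg/kg to 300 mg/kg. This estimate means a step of no change at the digits printed from compound 2 to compound 4 (within the scatter), expected to remain within the scatter.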

Compound 4, minimum effective dose: 300 mg/kg
Estimate against measurement, compound 4: 3.0-fold (0.48 log units) below; the measured number falls inside the stated range.
By their numbers in this assay, from the lowest: compound 3; then compound 2; then compounds 1 and 4 (each within the scatter of the next).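

The aromatic carbon para to a large group and meta to two chloro groups does not tolerate every change without consequence in this assay: chloro in place of hydrogen there gives a 3.0-fold higher number from compound 2 to compound 4 (0.48 log units; beyond the scatter). The earlier step, a 3.3-fold lower number from compound 2 to compound 3 (0.52 log units; beyond the scatter), replaced a chloro group with methyl and moved toward less compound being needed, whereas this first step at a carbon bearing hydrogen in compound 2 moves toward more compound being needed, so the two steps in the series now run in opposite directions from compound 2. Nothing available accounts for either direction, and the step stands as an observation only.

The compounds shown leave open whether this step belongs to chloro itself or would follow from any group at this carbon, a question that a methyl group, a methoxy group or an amine at the same place would address. They also leave open whether methyl in place of chloro at the other positions would give a step of similar size and direction on the background of compound 4.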